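Removing a Ring Fluorine: Does the Loss Repeat?

The compounds below may be only part of what the source reports. "The series", "measured", "known", "first", "only" and "open" are said of these compounds alone.

Of the compounds shown here, three have been measured in an ADME assay on microsomes from liver (Rattus norvegicus) for metabolic stability, with a stated time of 10 min, tested at 0.5 uM; a lower number here means that less of the compound is left, a higher number that more of the compound is left. Compound 1 `CC(C)COc1ncc(-c2cn(C)c3cc(C(=O)NS(C)(=O)=O)ccc23)cc1Cl` gives 66% in this assay. Compound 2 `CC(C)COc1ncc(-c2cn(C)c3cc(C(=O)NS(C)(=O)=O)c(F)cc23)cc1Cl`, which carries an additional fluoro on the shared core, gives 85% in this assay. Compound 3 `Cn1cc(-c2ccc(C(F)(F)F)cc2)c2cc(F)c(C(=O)NS(C)(=O)=O)cc21`, built on a different core, gives 99% in this assay, the highest of the three.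

The step from compound 2 to compound 1 is a single change: hydrogen in place of fluoro on an aromatic carbon. That step gave a number 19 percentage points lower from compound 2 to compound 1 (beyond the scatter).

Compound 4 `Cn1cc(-c2ccc(C(F)(F)F)cc2)c2ccc(C(=O)NS(C)(=O)=O)cc21` has not been measured. It differs from compound 3 by hydrogen in place of fluoro on an aromatic carbon, and the place of this change is described in the same words as for compound 2 and compound 1, so it is the same change made on a second core. How the core of compound 3 differs from the core of compound 2 is not broken down here.

Among the compounds with values here, whether the step repeats on the new core cannot be known in advance; the one earlier example is the only guide, and a single example is thin ground. Because compound 3 stands at 99%, close to the top of what the read-out can show, the fall in compound 4 may come out somewhat smaller than the earlier one. The step from compound 3 to compound 4 is expected to be a number 17 percentage points lower from compound 3 to compound 4 (beyond the scatter) in this assay. Compound 4 is therefore estimated at 82%, with a likely range from 65% to 97%.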

Compound 4, percent of the compound remaining: 74%
The estimate for compound 4 lay 8 percentage points above the measured number; the measured number falls inside the stated range.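

On the second core, hydrogen in place of fluoro on an aromatic carbon gave a number 25 percentage points lower from compound 3 to compound 4 (beyond the scatter) in this assay, so the loss seen on the first core appeared again. Within the data shown here, the two steps can be treated as one effect of about the same size, and in these two pairs the fluoro-bearing compound keeps more of its parent form: the same change on two cores in this assay, a number 19 percentage points lower (beyond the scatter) from compound 2 to compound 1 and a number 25 percentage points lower (beyond the scatter) from compound 3 to compound 4, 6 percentage points apart, within the scatter of two such steps This is still only two pairs on two cores in a single assay, so it supports carrying the change between these two cores, but it does not show that the step would hold on a third core, and it does not explain why the fluoro makes a difference.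

The compounds shown hold only fluoro or hydrogen at this place, ortho to the (methylsulfonyl)carbamoyl group, so it remains open whether chloro, methyl or methoxy there would leave as much compound as fluoro does. As far as these compounds go, all four compounds also carry the (methylsulfonyl)carbamoyl group itself, and what a carboxylic acid in its place would do to the percent remaining, with or without the fluoro, is equally open.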